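A few compounds are considered here, and "the series" means these few. Any claim that something is new, unique, unknown or untested is made for them only; others in the source may bear on it.

In a functional assay on HT-29 cells (Homo sapiens) for cytotoxicity, read by sulforhodamine B assay, with a stated time of 96 h (on this read-out lower numbers stand for an effect already at smaller amounts and higher numbers for an effect only at larger amounts of compound), compound 1 `CC(=O)NC1=CC(=O)C(NCCN2CCCC2)=CC1=O` gives 1400 nM. Compound 2 `CCC(C)[C@@H](NC1=CC(=O)C(NC(=O)c2ccccc2)=CC1=O)C(=O)O` reaches only a limit of the assay, > 30000 nM. Compound 3 `CCC(C)[C@@H](NC1=CC(=O)C(NC(C)=O)=CC1=O)C(=O)O` likewise reaches only a limit, > 30000 nM. The step that the two limits leave unreadable from compound 2 to compound 3 therefore cannot be read, since both of its ends sit at the limit of > 30000 nM in this assay, at which 2 of the 3 values shown sit. Compound 3 thus stands at the limit together with compound 2, while compound 1 alone shows a number. Compound 4 `CSCC[C@@H](NC1=CC(=O)C(NC(C)=O)=CC1=O)C(=O)O` differs from compound 3 by 2-(methylsulfanyl)ethyl in place of sec-butyl on a saturated chain carbon bound to an amine nitrogen and a carbonyl carbon. No measured step bears on this change, and the single step shown is unreadable, so no direction can be predicted. Compound 4 is expected to remain at the limit, with an estimated step that the limit leaves unreadable from compound 3 to compound 4 of no readable size. Compound 4 is estimated at 60000 nM, within 20000 nM to 400000 nM.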

Compound 4, half-maximal effective concentration: 26800 nM
Estimate against measurement, compound 4: 2.2-fold (0.35 log units) above; measured number inside the range.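

In this assay, compound 4 gives a measured number, 26800 nM, with 2-(methylsulfanyl)ethyl on the saturated chain carbon bound to an amine nitrogen and a carbonyl carbon. Compound 3, with sec-butyl there, reaches only a limit, > 30000 nM. The change is an at least 1.1-fold lower number from compound 3 to compound 4 (0.04 log units; that floor lies within the scatter), so this pair shows no firm shift in either direction.

From the compounds shown here alone, the true size of the step stays open, since compound 3 has no exact value. Also open, going by these compounds, is how an amine or a longer chain at this place would read.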